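From thiophen-3-yl to 4-aminophenyl on a shared core

The source may hold more compounds than are shown below. What is called first, only, known or untested is meant among the compounds shown, and "the series" means these compounds.

Compound 1 `CC(=O)c1ccc(-c2ccc3c(C(=O)Nc4cccc(F)c4)cc(=O)[nH]c3c2)cc1`: > 20000 nM, a limit of the assay
Compound 2 `COc1ccc(-c2ccc3c(C(=O)Nc4cccc(F)c4)cc(=O)[nH]c3c2)cc1`: 18000 nM
Compound 3 `O=C(Nc1cccc(F)c1)c1cc(=O)[nH]c2cc(-c3ccsc3)ccc12`: 4300 nM

All three results come from a functional assay on KYSE-410 cells (Homo sapiens) for antiproliferative activity, read by MTT assay, with a stated time of 72 h; on this read-out higher numbers stand for weaker inhibition and lower numbers for stronger inhibition. Compound 3 has the lowest value of the set, and only compound 2 offers a true number to compare it with, giving a 4.2-fold lower number from compound 2 to compound 3 (0.62 log units; beyond the scatter). The limit on compound 1 means that an at least 4.6-fold lower number from compound 1 to compound 3 (0.66 log units; beyond the scatter) is only a floor on the real size of that step.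

Compound 4 `Nc1ccc(-c2ccc3c(C(=O)Nc4cccc(F)c4)cc(=O)[nH]c3c2)cc1` has not yet been measured. Its difference from compound 3 is 4-aminophenyl in place of thiophen-3-yl on an aromatic carbon. The entering group has a six-membered aromatic ring of carbon only, as the matching groups in compound 1 and compound 2 do. The two steps to compound 3 therefore bear most directly on this change, and read backwards they point to a higher number. The swap between the groups carried on that ring gave an at least 1.1-fold lower number from compound 1 to compound 2 (0.04 log units; that floor lies within the scatter), which offers no firm guide to an amino group. The expected change is a modest one towards weaker inhibition, estimated as a 2.3-fold higher number from compound 3 to compound 4 (0.37 log units; beyond the scatter). For compound 4 the estimated value is 10000 nM, with an expected range from 3000 nM to 20000 nM.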

Compound 4, half-maximal inhibitory concentration: > 20000 nM
Compound 4 ended at the assay's limit; the forecaster's own chance of this, stated with the estimate: 20%; at least 2.0-fold (0.30 log units) between middle value and limit.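

The step to 4-aminophenyl shows in this assay that the advantage of compound 3 is not kept by this new six-membered ring, with an at least 4.6-fold higher number from compound 3 to compound 4 (0.66 log units; beyond the scatter). With an amino group added to the acetyl and methoxy examples, all three compounds carrying a six-membered aromatic ring of carbon only at this position now stand on the weak side of compound 3, and no compound shown goes against this. The amino and methoxy compounds cannot be ordered, with an at least 1.1-fold higher number from compound 2 to compound 4 (0.04 log units; that floor lies within the scatter), the step between the amino and acetyl compounds cannot be read, and the value of compound 4 is a limit of the assay, so these comparisons give no ranking of the groups on that ring: the limit of > 20000 nM in this assay, at which 2 of the 4 values shown sit.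

The compounds shown leave open whether the lower number of compound 3 belongs to its five-membered ring or to the absence of any further group on the ring, a question that a plain phenyl group could help settle. A furan-3-yl group would test whether the sulfur atom of thiophen-3-yl matters, and only a group that brings a phenyl compound below the limit could rank the substituents on that ring.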